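Propyl to Butyl on the Chloro Analogue

The source may report more compounds than this note shows. Statements on the series, on what has been measured and on what is new or still open speak of the compounds shown alone.

Measured compounds:
Compound 1, `CCCNC(=O)NS(=O)(=O)c1ccc(-n2nc(-c3ccc(C)cc3)ccc2=O)cc1`, gives 80.5% in a functional assay on the whole organism (blood, strain Wistar albino) for inhibition, with Rattus norvegicus as the target, read by colorimetric assay, with stated times of 15 min and 90 min, at a dose of 20 mg/kg by the oral route; on this read-out higher numbers stand for more inhibition at the one dose given (going by the name of the read-out) and lower numbers for less inhibition.
Compound 2, `CCCCNC(=O)NS(=O)(=O)c1ccc(-n2nc(-c3ccc(C)cc3)ccc2=O)cc1`, gives 86.6% in this assay.
Compound 3, `CCCNC(=O)NS(=O)(=O)c1ccc(-n2nc(-c3ccc(Cl)cc3)ccc2=O)cc1`, gives 74.3% in this assay.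

Compound 4, `CCCCNC(=O)NS(=O)(=O)c1ccc(-n2nc(-c3ccc(Cl)cc3)ccc2=O)cc1`, has not yet been measured. Compound 1 and compound 2 differ by methyl in place of hydrogen on a saturated chain carbon, three bonds along the chain from an amide-type nitrogen, and this change gives a number 6.1 percentage points higher from compound 1 to compound 2 (within the scatter). Compound 3 differs from compound 1 by chloro in place of methyl on an aromatic carbon, which gives a number 6.2 percentage points lower from compound 1 to compound 3 (within the scatter). Compound 4 stands to compound 3 as compound 2 stands to compound 1, by methyl in place of hydrogen on a saturated chain carbon, three bonds along the chain from an amide-type nitrogen; the place is the same in both cases, and the change is the same kind of change, made this time on the core of compound 3 rather than that of compound 1. Against compound 3 in this assay the step is therefore expected to be about a number 5.7 percentage points higher from compound 3 to compound 4 (within the scatter), because the same change on compound 1 gave a number 6.1 percentage points higher from compound 1 to compound 2 (within the scatter), a step within the scatter. The estimate for compound 4 in this assay is accordingly 80%, between 68% and 90%.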

Compound 4, a percentage reported as inhibition, in the whole organism at one dose (the size of the read-out at that dose, not a potency): 66%
Estimate against measurement, compound 4: 14 percentage points above; measured number outside the range, below it.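

On the core of compound 3, propyl to butyl gives a number 8.3 percentage points lower from compound 3 to compound 4 (within the scatter), and in this assay this change does not carry over as a fixed step from the core of compound 1: the same change on two cores in this assay, a number 6.1 percentage points higher (within the scatter) from compound 1 to compound 2 and a number 8.3 percentage points lower (within the scatter) from compound 3 to compound 4, 14.4 percentage points apart, beyond the scatter of two such steps. Chloro in place of methyl, read on the butyl compounds, gives a number 20.6 percentage points lower from compound 2 to compound 4 (beyond the scatter), and this step likewise differs from the one on the propyl compounds: the same change on two cores in this assay, a number 6.2 percentage points lower (within the scatter) from compound 1 to compound 3 and a number 20.6 percentage points lower (beyond the scatter) from compound 2 to compound 4, 14.4 percentage points apart, beyond the scatter of two such steps. Among these compounds, each chain step taken alone lies within the scatter, so the result shows only that the two changes do not add up across these four compounds; it does not show that butyl itself raises or lowers the number on either core, why the steps differ, or whether the same would hold on any other core.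

The compounds shown leave open whether a longer chain such as pentyl, or a cyclohexyl ring in place of the chain, would follow the pattern of the methyl compounds or that of the chloro compounds. They also leave open how propyl and butyl would compare with a fluoro or methoxy group in place of the chloro.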